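The source may report more compounds than this note shows. Statements on the series, on what has been measured and on what is new or still open speak of the compounds shown alone.

Measured compounds:
- compound 1, `COCCNC(=O)C[C@H](NC(=O)c1ccc(C#Cc2ccccc2)cc1)C(=O)NO`: 2
- compound 2, `CSC[C@H](NC(=O)c1ccc(C#Cc2ccccc2)cc1)C(=O)NO`: 3
- compound 3, `O=C(C[C@H](NC(=O)c1ccc(C#Cc2ccccc2)cc1)C(=O)NO)NCCCO`: 2

In a physicochemical assay for lipophilicity (on this read-out lower numbers stand for lower lipophilicity and higher numbers for higher lipophilicity), compound 3 stands level with compound 1, the two together giving the lowest of the three numbers. Its nearest neighbour is compound 1, with no change at the digits printed from compound 1 to compound 3 (within the scatter), and its furthest is compound 2, since a number 1.00 log units lower from compound 2 to compound 3 (beyond the scatter).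

Compound 4, `O=C(CNC(=O)c1ccc(C#Cc2ccccc2)cc1)NO`, has not yet been measured. It differs from compound 3 in a single place: hydrogen in place of ((3-hydroxypropyl)carbamoyl)methyl on a saturated chain carbon bound to an amide-type nitrogen and a carbonyl carbon. The whole side chain carrying the amide and the hydroxyl is thus gone.

Going by the values given here, two measured steps bear on this. Swapping the carbamoyl-type chain for methylsulfanyl gave a number 1.00 log units higher from compound 1 to compound 2 (beyond the scatter), and the reverse swap gave a number 1.00 log units lower from compound 2 to compound 3 (beyond the scatter). Removing that chain altogether should move compound 4 in the same direction as compound 2, but hydrogen is a smaller group than methylsulfanyl, so a smaller rise is expected. The estimated step is a number 0.30 log units higher from compound 3 to compound 4 (within the scatter). In this assay compound 4 is expected to give about 2.3, within 1.7 to 2.9.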

Compound 4, distribution coefficient: 3
For compound 4 the middle estimate is 0.70 log units below the measured one; measured number outside the range, above it.
By their numbers in this assay, from the lowest: compounds 1 and 3 (each within the scatter of the next); then compounds 2 and 4 (each within the scatter of the next).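

In this assay, taking the whole side chain away gives a number 1.00 log units higher from compound 3 to compound 4 (beyond the scatter) and likewise a number 1.00 log units higher from compound 1 to compound 4 (beyond the scatter) so the loss of either carbamoyl-bearing chain counts for as much as the earlier swap to methylsulfanyl. Against the smaller chain, hydrogen gives no change at the digits printed from compound 2 to compound 4 (within the scatter) so (methylsulfanyl)methyl and hydrogen stand together on this saturated chain carbon. Among these four compounds, the two chains carrying a carbamoyl group, ((3-hydroxypropyl)carbamoyl)methyl and ((2-methoxyethyl)carbamoyl)methyl, go with the lower number, and no measurement shown here gives a cause for that.

On these data alone, what remains open is whether the carbamoyl group itself sets this split or whether other chains would share it. A carboxylic acid, an amine or a plain longer carbon chain on this carbon could fall on either side.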